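Chloromethyl for furan-2-yl: cytotoxicity at the assay limit

The compounds below may be only part of what the source reports. "The series", "measured", "known", "first", "only" and "open" are said of these compounds alone.

Compound 1 `CCOC(=O)c1csc2nc(-c3cccc(NC(=O)c4ccco4)c3)cn12`, in a functional assay on HeLa cells (Homo sapiens) for cytotoxicity, read by MTT assay, with a stated time of 72 h; a higher number here means a weaker inhibitor, a lower number a stronger inhibitor: > 20000 nM, which is a limit of the assay and not a number.
Compound 2 `CCOC(=O)c1csc2nc(-c3ccc(NC(=O)c4ccco4)cc3)cn12`, in this assay: > 20000 nM, again a limit of the assay.
Compound 3 `CCOC(=O)c1csc2nc(-c3cccc(NC(=O)CCl)c3)cn12`, in this assay: 20000 nM.

The difference between the cores of compound 1 and compound 2 is not broken down here. From compound 1 to compound 3 the change is chloromethyl in place of furan-2-yl on a carbonyl carbon, and a number no higher from compound 1 to compound 3 (the limit leaves the size open); its size cannot be read because of the limit of > 20000 nM in this assay, at which 2 of the 3 values shown sit.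

Compound 4 `CCOC(=O)c1csc2nc(-c3ccc(NC(=O)CCl)cc3)cn12` carries the same change from compound 2, namely (chloromethyl in place of furan-2-yl on a carbonyl carbon). Since the measured step from compound 1 to compound 3 left no readable size, only a small step is expected, a number no higher from compound 2 to compound 4 (the limit leaves the size open). Compound 4 is therefore estimated at 20000 nM, with a likely range from 8000 nM to 50000 nM, and it may well be reported only as a limit again.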

Compound 4, half-maximal inhibitory concentration: > 20000 nM
Compound 4: a limit, no number; the forecaster's own chance of this, stated with the estimate: 60%; the middle value lies on the limit itself.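

Compound 2 and compound 4 both stand only as limits of the assay, not numbers, so no step between them can be read: the limit of > 20000 nM in this assay, at which 3 of the 4 values shown sit.

Going by these compounds, whether chloromethyl in place of furan-2-yl changes cytotoxicity in this pair stays open.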